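Nitro for hydroxy on the shared core

This account rests on a few compounds, and the source may have more. Where it says the series, first, only, none or still open, it means among the compounds named here.

Measured compounds:
Compound 1, `COc1ccc(C2SCC(=O)N2CCN2CCCCC2)cc1`, 89%
Compound 2, `O=C1CSC(c2cccc(O)c2)N1CCN1CCCCC1`, 100%
Compound 3, `O=C1CSC(c2ccc(O)cc2)N1CCN1CCCCC1`, 94%

In an ADME assay on Vero cells (Chlorocebus sabaeus) for cytotoxicity, read by neutral red uptake, tested at 98 ug/mL (on this read-out higher numbers stand for a weaker effect at the one concentration tested and lower numbers for a stronger effect), compound 3 stands second highest of the three numbers, yet all three lie within the scatter of one another: compound 1 is its nearest neighbour, with a number 5 percentage points higher from compound 1 to compound 3 (within the scatter), and compound 2 its furthest, with a number 6 percentage points lower from compound 2 to compound 3 (within the scatter). Neither step moves the read-out beyond what repeated measurements of this kind usually show, so the three compounds give the same picture on this read-out.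

Compound 4, `O=C1CSC(c2ccc([N+](=O)[O-])cc2)N1CCN1CCCCC1`, has not yet been measured. It differs from compound 3 in one place: nitro in place of hydroxy on an aromatic carbon. Among the compounds with values here, no measured step touches a nitro group, so the two steps above bear on compound 4 only indirectly, by showing that changes at or around the hydroxy-bearing ring left the read-out in this assay unmoved. On that basis the step from compound 3 to compound 4 is expected to stay within the scatter, a number 2 percentage points lower from compound 3 to compound 4 (within the scatter). For compound 4 in this assay a value of 92% is therefore estimated, with a range from 78% to 100%.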

Compound 4, a percentage reported as activity, at one concentration (the size of the read-out at that concentration, not a potency): 87%
Compound 4: the middle estimate sits 5 percentage points above what was measured; the range from low to high includes it.
By their numbers in this assay, from the lowest: compounds 4, 1, 3 and 2 (each within the scatter of the next, the first and the last beyond it).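

Nitro in place of hydroxy, on an aromatic carbon para to a large group, is the first change shown that puts a group containing nitrogen at this position, and it goes from 1 hydrogen-bond donor to 0 hydrogen-bond donors; in this assay it gives a number 7 percentage points lower from compound 3 to compound 4 (within the scatter), and nitro in place of methoxy gives a number 2 percentage points lower from compound 1 to compound 4 (within the scatter). At this position, then, hydroxy, methoxy and nitro cannot be told apart on this read-out, a pattern that rests on compound 1, compound 3 and compound 4 alone and that none of the three goes against. No measurement shown here accounts for this result.

The compounds shown leave open whether an amine, a carboxylic acid or a halogen such as fluorine on the same aromatic carbon would also stay within the scatter, and whether nitro would do so on the ring carbon that carries the hydroxy in compound 2. They also leave open what these compounds do at any other concentration, since a reading at one concentration is not a potency.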